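The source may hold more compounds than are shown below. What is called first, only, known or untested is meant among the compounds shown, and "the series" means these compounds.

Measured so far:

Compound 1, `c1ccc(-c2cn3ccnc3c(-c3ccc4ncn(C5CCCCC5)c4c3)n2)cc1`: in a functional assay on NCI-H522 cells (Homo sapiens) for inhibition, read by sulforhodamine B assay, with a stated time of 48 h, tested at 10 uM (on this read-out lower numbers stand for less inhibition and higher numbers for more inhibition at the one concentration tested (going by the name of the read-out)), compound 1 gives 58.1%.
Compound 2, `Clc1ccc(-c2cn3ccnc3c(-c3ccc4ncn(C5CCCCC5)c4c3)n2)cc1`: in this assay compound 2 gives 19.8%.

Going by the values given here, compound 1 stands highest of the two numbers in this assay; its nearest neighbour is compound 2, and the single measured step, a number 38.3 percentage points lower from compound 1 to compound 2 (beyond the scatter), is a large drop beyond the scatter for chloro in place of hydrogen on an aromatic carbon.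

Compound 3, `COc1ccccc1-c1cn2ccnc2c(-c2ccc3ncn(C4CCCCC4)c3c2)n1`, is not yet measured. It differs from compound 1 by methoxy in place of hydrogen on an aromatic carbon.

Among the compounds with values here, the only step that bears on this change is a number 38.3 percentage points lower from compound 1 to compound 2 (beyond the scatter). It shows that a substituent entering the phenyl ring of compound 1 can cost much inhibition in this assay, but the group there is chloro and it sits at a different place on the ring; nothing measured in the series carries a methoxy group, so the transfer is loose. A loss of some size is the more likely outcome, yet an outcome within the scatter cannot be excluded.

For compound 3 the expected step is a number 16.1 percentage points lower from compound 1 to compound 3 (beyond the scatter). Compound 3 is therefore estimated at 42% in this assay, with a range of 15% to 68%.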

Compound 3, a percentage reported as inhibition, at one concentration (the size of the read-out at that concentration, not a potency): 22.2%
Compound 3: the middle estimate sits 19.8 percentage points above what was measured; low and high end bracket the measured number.
By their numbers in this assay, from the lowest: compounds 2 and 3 (each within the scatter of the next); then compound 1.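

In this assay the methoxy group on an aromatic carbon, ortho to a large group, brings a number 35.9 percentage points lower from compound 1 to compound 3 (beyond the scatter) and so shows that a large loss is not confined to the chloro group of compound 2. The change from 4-chlorophenyl to 2-methoxyphenyl gives a number 2.4 percentage points higher from compound 2 to compound 3 (within the scatter) and does not separate these two substituted rings, although both the group and its place differ. Among the compounds shown, the plain phenyl of compound 1 therefore stands alone above both substituted rings, and no measurement at hand explains the loss.

From the compounds shown here alone, whether the loss extends to other groups remains open: an amine, a carboxylic acid or a longer chain such as ethoxy on the same ring would test how general it is. Also open is how much the place on the ring matters, since chloro and methoxy are each shown at only one place, and a 4-methoxyphenyl or 2-chlorophenyl compound would separate the group from its position.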